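Halogen removal on the fused core and microsomal stability

The source may hold more compounds than are shown below. What is called first, only, known or untested is meant among the compounds shown, and "the series" means these compounds.

Compound 1 `O=S(=O)(c1ccc(F)cc1)c1cnc2cc(Cl)c(F)cc2c1-c1ccc(Cl)cc1` carries both a chloro and a fluoro group on the fused core; in an ADME assay on microsomes from liver (Homo sapiens) for metabolic stability, tested at 2.5 uM (a lower number here means slower removal, a higher number faster removal of the compound), compound 1 gives 0.01 mL/min. Compound 2 `O=S(=O)(c1ccc(F)cc1)c1cnc2cc(Cl)ccc2c1-c1ccc(Cl)cc1` retains the chloro group only, and in this assay compound 2 gives 0.21 mL/min. For the measured compounds named here, the single measured step is a 21-fold higher number from compound 1 to compound 2 (1.32 log units; beyond the scatter). Among the two numbers so far, compound 1 stands lowest, with compound 2 as its only neighbour.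

Compound 3 `O=S(=O)(c1ccc(F)cc1)c1cnc2ccc(F)cc2c1-c1ccc(Cl)cc1` differs from compound 1 in one place: hydrogen in place of chloro on an aromatic carbon. Going by the values given here, no measured step removes a chloro group; the one step available, a 21-fold higher number from compound 1 to compound 2 (1.32 log units; beyond the scatter), removes the fluoro group from the same core and is large and upward. By analogy, removal of a halogen from this core is expected to raise the number in this assay, though the size for chloro is not anchored by any measurement, so a wide range is carried. For compound 3 the expected step is a 6.0-fold higher number from compound 1 to compound 3 (0.78 log units; beyond the scatter). Compound 3 is therefore estimated at 0.06 mL/min, with a range from 0.01 mL/min to 0.3 mL/min.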

Compound 3, intrinsic clearance in a liver preparation (reported as CLH), per the amount of preparation that the assay uses: 0.12 mL/min
For compound 3 the middle estimate is 2.0-fold (0.30 log units) below the measured one; measured number inside the range.
By their numbers in this assay, from the lowest: compound 1; then compounds 3 and 2 (each within the scatter of the next).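

The chloro position now has a measured step of its own in this assay: a 12-fold higher number from compound 1 to compound 3 (1.08 log units; beyond the scatter), for hydrogen in place of chloro on the aromatic carbon ortho to a fluoro group. The earlier step, a 21-fold higher number from compound 1 to compound 2 (1.32 log units; beyond the scatter), covered only the fluoro group, so the series now shows that removing either halogen from the core of compound 1 gives a large upward step in the same direction, and compound 1 stands lowest, with both steps beyond the scatter. No measurement on hand explains why either halogen has this effect on the number.

Open, on these data alone, is whether a group other than a halogen on this carbon, such as a methyl, a methoxy or a nitrile, would keep the number as low as in compound 1, or whether only chloro does so. Also open, as far as these compounds go, is how the shared core behaves with hydrogen at both halogen places, and whether the chloro step keeps its size when the fluoro group is absent, since it has been read only with that fluoro group present.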